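Sulfonyl substituent exchange in a serotonin receptor binding series

This account rests on a few compounds, and the source may have more. Where it says the series, first, only, none or still open, it means among the compounds named here.

Measured compounds:
compound 1 `CC(C)(C)OC(=O)N1CC=C(c2cn(S(=O)(=O)c3ccccc3)c3ccccc23)CC1`: 54 nM
compound 2 `O=S(=O)(c1ccccc1Cl)n1cc(C2=CCNCC2)c2ccccc21`: 0.4 nM

In an assay on HeLa cells for binding affinity to 5-hydroxytryptamine receptor 6 (Homo sapiens) (on this read-out lower numbers stand for stronger inhibition and higher numbers for weaker inhibition), compound 1 gives 54 nM while compound 2 gives 0.4 nM, so compound 2 holds the lower of the two numbers, well apart from compound 1. Compound 3 `O=S(=O)(c1ccc(Cl)s1)n1cc(C2=CCNCC2)c2ccccc21` differs from compound 2 by 5-chlorothiophen-2-yl in place of 2-chlorophenyl on a sulfonyl sulfur. Within the data shown here, no pair of measured compounds shows this exchange, so its effect is unknown here. A small step is expected, a 2.5-fold higher number from compound 2 to compound 3 (0.40 log units; beyond the scatter), at most a modest rise rather than a loss of the same order as the gap to compound 1. Compound 3 is estimated at 1 nM, within 0.2 nM to 5 nM.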

Compound 3, inhibition constant: 3 nM
Compound 3: the middle estimate sits 3.0-fold (0.48 log units) below what was measured, within the range that was stated.
By their numbers in this assay, from the lowest: compound 2; then compound 3; then compound 1.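

In this assay the aromatic ring on the sulfonyl sulfur can be exchanged with only a modest loss: a 7.5-fold higher number from compound 2 to compound 3 (0.88 log units; beyond the scatter), and compound 3 still reads 3 nM. A five-membered aromatic ring with one hetero atom is therefore accepted here in place of a six-membered carbon ring. No measured evidence accounts for the size of this step.

From the compounds shown here alone, what the chlorine contributes on either ring remains open. So does the reading of a pyridine ring or a methoxy-bearing phenyl on the sulfonyl sulfur.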